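The source may report more compounds than this note shows. Statements on the series, on what has been measured and on what is new or still open speak of the compounds shown alone.

Measured so far in a functional assay on SK-MEL-28 cells (Homo sapiens) for inhibition, read by colorimetric assay and MTT assay, with a stated time of 72 h; a lower number here means a stronger inhibitor, a higher number a weaker inhibitor:
compound 1, `O=C(NNC(=S)Nc1csc(-c2ccccc2)c1)c1ccc(O)cc1`: 71000 nM
compound 2, `Cc1ccc(-c2cc(NC(=S)NNC(=O)c3ccc(O)cc3)cs2)cc1`: 46000 nM
compound 3, `COc1ccc(C(=O)NNC(=S)Nc2csc(-c3ccccc3)c2)cc1OC`: 28000 nM

Compound 1 and compound 2 share one core; the change between them is methyl in place of hydrogen on an aromatic carbon, and in this assay it made a 1.5-fold lower number from compound 1 to compound 2 (0.19 log units; within the scatter). Compound 3 carries a different core; the difference between the two cores is not broken down here. The number for compound 3 sits within the scatter of that for compound 2, while the gap from compound 3 to compound 1 lies beyond the scatter, so only the latter pair can be told apart.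

Compound 4, `COc1ccc(C(=O)NNC(=S)Nc2csc(-c3ccc(C)cc3)c2)cc1OC`, has not yet been measured. Against compound 3 it shows (methyl in place of hydrogen on an aromatic carbon), the same change as from compound 1 to compound 2, at the same place. Within the data shown here, the one measured instance of this change, a 1.5-fold lower number from compound 1 to compound 2 (0.19 log units; within the scatter), stayed within the scatter; the expectation for compound 4 is therefore a step of about a 1.4-fold lower number from compound 3 to compound 4 (0.15 log units; within the scatter) from compound 3, resting on that single precedent. Compound 4 is estimated at 20000 nM, with a plausible range of 9000 nM to 45000 nM.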

Compound 4, half-maximal inhibitory concentration: 19000 nM
Compound 4: the middle estimate sits 1.1-fold (0.02 log units) above what was measured; low and high end bracket the measured number.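

In this assay, phenyl to 4-methylphenyl gives a 1.5-fold lower number from compound 3 to compound 4 (0.17 log units; within the scatter), and the agreement with the earlier step is direct: the same change on two cores in this assay, a 1.5-fold lower number (0.19 log units; within the scatter) from compound 1 to compound 2 and a 1.5-fold lower number (0.17 log units; within the scatter) from compound 3 to compound 4, 1.0-fold (0.02 log units) apart, within the scatter of two such steps.

Within these two pairs, then, the methyl step carries from one core to the other with no difference that this assay can resolve. Among these compounds, each step stays within the scatter on its own, so the pairs do not show that methyl in place of hydrogen moves the number at all, only that neither core departs from the other; two cores and a single place also give no basis for extending this to the rest of the series.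

The compounds shown carry only hydrogen or methyl at this place on the six-membered aromatic ring, so it remains open whether chlorine, an amine, a carboxylic acid or a longer chain such as butyl there would give a step beyond the scatter. As far as these compounds go, it also remains open whether any such step would carry between the two cores as the methyl step does.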